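Propyl to isopropyl beside an amide, estimated from a sulfonamide pair

The source may hold more compounds than are shown below. What is called first, only, known or untested is meant among the compounds shown, and "the series" means these compounds.

Measured compounds in a functional assay on K562 cells (Homo sapiens) for antiproliferative activity, read by CCK-8 assay, with a stated time of 72 h; on this read-out lower numbers stand for stronger inhibition of growth and higher numbers for weaker inhibition of growth:
Compound 1 `CCC1C(=O)N(C)c2cnc(Nc3ccc(S(=O)(=O)NCC(C)C)cc3)nc2N1c1ccn(C)n1` gives 7300 nM.
Compound 2 `CCCCNS(=O)(=O)c1ccc(Nc2ncc3c(n2)N(c2ccn(C)n2)C(CC)C(=O)N3C)cc1` gives 4240 nM.
Compound 3 `CCCCNC(=O)c1ccc2c(ccn2-c2ncc3c(n2)N(C2CCCC2)[C@H](CC)C(=O)N3C)c1` gives 673 nM.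

Compound 4 `CC[C@@H]1C(=O)N(C)c2cnc(-n3ccc4cc(C(=O)NCC(C)C)ccc43)nc2N1C1CCCC1` has not been measured. It is made from compound 3 by one change, (isopropyl in place of propyl on a saturated chain carbon bound to an amide-type nitrogen). The same change, at a different place, has been made once before: compound 1 is made from compound 2 by isopropyl in place of propyl on a saturated chain carbon bound to a sulfonamide nitrogen, and in this assay that step is a 1.7-fold higher number from compound 2 to compound 1 (0.24 log units; within the scatter). The two places are not the same word for word, one being a sulfonamide nitrogen and the other an amide-type nitrogen, so the change is of the same kind rather than the same. How the core of compound 3 differs from that of compound 2 is not broken down here. Because the earlier step was a 1.7-fold higher number from compound 2 to compound 1 (0.24 log units; within the scatter), the step from compound 3 to compound 4 is expected to be small, about a 1.4-fold higher number from compound 3 to compound 4 (0.15 log units; within the scatter). Compound 4 is therefore estimated at 950 nM, between 400 nM and 2200 nM.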

Compound 4, concentration for 50% growth inhibition: 638 nM
Estimate against measurement, compound 4: 1.5-fold (0.17 log units) above; measured number inside the range.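

In this assay, isopropyl in place of propyl gives a 1.1-fold lower number from compound 3 to compound 4 (0.02 log units; within the scatter), so the two numbers cannot be told apart. Set beside the earlier case, the change looks alike on the two cores: the same change on two cores in this assay, a 1.7-fold higher number (0.24 log units; within the scatter) from compound 2 to compound 1 and a 1.1-fold lower number (0.02 log units; within the scatter) from compound 3 to compound 4, 1.8-fold (0.26 log units) apart, within the scatter of two such steps This shows only that the change stayed small in these two pairs, one at a sulfonamide nitrogen and one at an amide-type nitrogen; it does not show that it would stay small on any other core.

The compounds shown leave open whether a larger change in the same place would register in this assay. A longer chain such as hexyl, or a chain ending in an amine or a carboxylic acid, in place of the isobutyl of compound 4 would test this.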